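Changing the Amide Aryl Group in a Cytotoxicity Series

The source may hold more compounds than are shown below. What is called first, only, known or untested is meant among the compounds shown, and "the series" means these compounds.

Of the compounds shown here, three built on one shared core have been tested in an ADME assay on HCT-116 cells (Homo sapiens) for cytotoxicity, read by MTT assay, with a stated time of 72 h; a lower number here means a stronger inhibitor, a higher number a weaker inhibitor. Compound 1 `CCc1cccc(NC(=O)c2cccc(/C=C3\CC(=O)N(Cc4ccccc4)C3=O)c2)c1` gives 80600 nM. Compound 2 `CCc1cccc(NC(=O)c2cccc(/C=C3\CC(=O)N(c4ccccc4)C3=O)c2)c1` gives 81200 nM. Compound 3 `CCc1cccc(NC(=O)c2cccc(/C=C3\CC(=O)N(c4ccc(C)cc4)C3=O)c2)c1` gives 41500 nM. Compound 2 carries the highest of the three numbers, yet the gaps are small: a 1.0-fold higher number from compound 1 to compound 2 (0.00 log units; within the scatter), and a 2.0-fold lower number from compound 2 to compound 3 (0.29 log units; within the scatter), so the three values cannot be told apart with confidence.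

Compound 4 `O=C(Nc1ccc(Cl)cc1)c1cccc(/C=C2\CC(=O)N(c3ccccc3)C2=O)c1` has not been measured. Compared with compound 2, the change is 4-chlorophenyl in place of 3-ethylphenyl on an amide-type nitrogen.

All three measured steps, a 1.0-fold higher number from compound 1 to compound 2 (0.00 log units; within the scatter), a 1.9-fold lower number from compound 1 to compound 3 (0.29 log units; within the scatter) and a 2.0-fold lower number from compound 2 to compound 3 (0.29 log units; within the scatter), concern the group on the amide-type nitrogen in the ring. The change to compound 4 sits at a different amide-type nitrogen, one whose other neighbour is a carbonyl carbon. Within the data shown here, no measured step therefore bears on this change, and the data offer no guidance on its direction. What they do show is that every variation tried so far left the number within the scatter, so a step of a 1.0-fold lower number from compound 2 to compound 4 (0.01 log units; within the scatter) is expected, with no change beyond the scatter anticipated. Compound 4 is thus estimated at 80000 nM, within a range from 30000 nM to 200000 nM.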

Compound 4, half-maximal inhibitory concentration: > 100000 nM
Compound 4: a limit, no number (the forecaster's own chance of this, stated with the estimate: 25%); middle value at least 1.2-fold (0.09 log units) away from the limit.
By their numbers in this assay, from the lowest: compounds 3, 1 and 2 (each within the scatter of the next). At a limit, above all of these: compound 4.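

In this assay, compound 4 gives > 100000 nM, which is a limit of the assay and not a number. Among these compounds, this is the first reading at the amide-type nitrogen whose other neighbour is a carbonyl carbon, since the earlier compounds varied only the group on the nitrogen in the ring, and putting 4-chlorophenyl in place of 3-ethylphenyl gives a step of an at least 1.2-fold higher number from compound 2 to compound 4 (0.09 log units; that floor lies within the scatter). The change shows no sign of a stronger inhibitor, but its true size stays unknown, and the reading can only be placed at the top of the measurable range: the limit of > 100000 nM in this assay, at which 1 of the 4 values shown sits.

Since the swap removes the ethyl group and brings in a chlorine in a single change, the compounds shown cannot say which of the two matters, or whether the same swap would read alike with benzyl or 4-methylphenyl on the ring nitrogen. Also open, as far as these compounds go, is how this position would respond to an aryl group bearing an amine, a carboxylic acid or a longer chain, any of which could show whether a number well clear of the scatter can be reached here.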